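Changing the Aryl Group on a Fatty-Chain Urea

The source may hold more compounds than are shown below. What is called first, only, known or untested is meant among the compounds shown, and "the series" means these compounds.

Compound 1, `CCCCCCCC/C=C\CCCCCCCCNC(=O)Nc1c(C)cccc1C`: 160 nM
Compound 2, `CCCCCCCC/C=C\CCCCCCCCNC(=O)Nc1cc(C)ccc1C`: 4500 nM
Compound 3, `CCCCCCCC/C=C\CCCCCCCCNC(=O)Nc1ccc(F)cc1F`: 4700 nM

Three ureas sharing one long unsaturated chain were tested in an assay on microsomes from intestinal mucosa for inhibition of acyl-CoA:cholesterol acyltransferase (Oryctolagus cuniculus); a lower number here means a stronger inhibitor, a higher number a weaker inhibitor. Compound 1, which carries a 2,6-dimethylphenyl group, gives the lowest number of the three. Compound 3, with a 2,4-difluorophenyl group, stands at the top of the range: its number sits within the scatter of compound 2 (a 1.0-fold higher number from compound 2 to compound 3 (0.02 log units; within the scatter)), but far from compound 1 (a 29-fold higher number from compound 1 to compound 3 (1.47 log units; beyond the scatter)). So two of the three aryl groups give weak inhibition, and only the 2,6-dimethylphenyl pattern of compound 1 gives strong inhibition.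

Compound 4, `CCCCCCCC/C=C\CCCCCCCCNC(=O)Nc1ccccc1CC`, has not yet been measured. Its difference from compound 3 is 2-ethylphenyl in place of 2,4-difluorophenyl on an amide-type nitrogen. Among the compounds with values here, no measured step covers a 2-ethylphenyl group, so the steps from compound 1 to compounds 2 and 3 are the only guide: each shows that the aryl group alone can move the number by a large amount. A single alkyl group on the ring, as in compound 4, shares part of the pattern of compound 1 but not all of it, so a number between compound 1 and compound 3 is expected, closer to compound 3. The estimated step in this assay is a 3.1-fold lower number from compound 3 to compound 4 (0.50 log units; beyond the scatter). For compound 4 the expected value is 1500 nM, with a range from 400 nM to 6000 nM.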

Compound 4, half-maximal inhibitory concentration: 980 nM
Compound 4: the middle estimate sits 1.5-fold (0.18 log units) above what was measured; low and high end bracket the measured number.
By their numbers in this assay, from the lowest: compound 1; then compound 4; then compounds 2 and 3 (each within the scatter of the next).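

In this assay, the 2-ethylphenyl group separates clearly from both weak aryl groups, with a 4.8-fold lower number from compound 3 to compound 4 (0.68 log units; beyond the scatter) and a 4.6-fold lower number from compound 2 to compound 4 (0.66 log units; beyond the scatter). It does not reach the level of the 2,6-dimethylphenyl group, with a 6.1-fold higher number from compound 1 to compound 4 (0.79 log units; beyond the scatter), so the aryl groups on this nitrogen now fall into three levels: compound 1, then compound 4, then compounds 2 and 3, which cannot be told apart. The number of alkyl groups on the ring does not by itself set this order, since compound 2 carries two methyl groups and still gives a higher number than compound 4, which carries one ethyl group.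

No supporting measurement bears on why these aryl groups differ. The compounds shown leave open whether the size of the alkyl group, the presence of two groups on the ring, or both, separates compound 1 from compound 4.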